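Trading a benzyl for a dimethylamino on the side chain

The compounds below may be only part of what the source reports. "The series", "measured", "known", "first", "only" and "open" are said of these compounds alone.

Of the compounds shown here, three sharing one core have been measured in an assay on HEK293 cells for agonist activity at Toll-like receptor 8 (Homo sapiens), read by spectrophotometry; on this read-out lower numbers stand for an effect already at smaller amounts and higher numbers for an effect only at larger amounts of compound. Compound 1, `CCCCNc1nc(N)nc(C)c1CCCCc1ccccc1`, gives 857 nM. Compound 2, `CCCCNc1nc(N)nc(C)c1CCCn1c(C)nc2ccccc21`, gives 366 nM, and compound 3, `CCCCNc1nc(N)nc(C)c1CC`, gives 1660 nM. Among these three numbers compound 1 holds the second highest; its number and that of compound 3 lie within the usual scatter of this assay, so nothing can be said about an order between them, while the number of compound 2 lies lower by a margin beyond the scatter.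

Compound 4, `CCCCNc1nc(N)nc(C)c1CCCN(C)C`, has not yet been measured. Relative to compound 1 the change is dimethylamino in place of benzyl on a saturated chain carbon, three bonds along the chain from an aromatic carbon. Put simply, the flexible chain still reaches three carbons out from the core, but the aromatic ring at its end is gone and a small nitrogen-bearing group takes its place. For the measured compounds named here, no measured pair shows this exact exchange, so the expected size of the step comes from what the three numbers suggest: the shortest chain of compound 3 gives 1660 nM, and the expectation is that compound 4 lands somewhat nearer to that, with a step from compound 1 of a 1.4-fold higher number from compound 1 to compound 4 (0.15 log units; within the scatter), a modest move towards a higher number that may not exceed the scatter. The estimate for compound 4 is 1200 nM, with a likely range from 400 nM to 3500 nM.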

Compound 4, half-maximal effective concentration: 126 nM
Beside the measured number, compound 4's estimate is 9.5-fold (0.98 log units) above it; the whole stated range lies above it.
By their numbers in this assay, from the lowest: compound 4; then compound 2; then compounds 1 and 3 (each within the scatter of the next).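

In this assay, dimethylamino in place of benzyl on a saturated chain carbon, three bonds along the chain from an aromatic carbon, gives a 6.8-fold lower number from compound 1 to compound 4 (0.83 log units; beyond the scatter), so among these compounds the aromatic ring at the chain end is not needed for a low number, and a smaller group containing nitrogen does better. The step of a 13-fold lower number from compound 3 to compound 4 (1.12 log units; beyond the scatter), with (dimethylamino)methyl in place of hydrogen on a saturated chain carbon, two bonds along the chain from an aromatic carbon, shows that extending the short chain can matter a great deal, whereas compound 1 and compound 3 lie within the scatter of each other, so the chain ending in benzyl showed no readable change of this kind. Nothing available here explains why the nitrogen-bearing group goes with the lower number.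

An isopropyl group, with carbon where the nitrogen stands, would show whether the nitrogen itself matters or only the loss of the ring. Other amines at the chain end, such as a primary amine or a pyrrolidine, and a longer chain carrying the same dimethylamino group remain open as well.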